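Methoxy for hydroxy on a urea-linked pyrazole series

The compounds below may be only part of what the source reports. "The series", "measured", "known", "first", "only" and "open" are said of these compounds alone.

Measured compounds:
compound 1 `COc1cc(Cl)cc(-c2nn(-c3cccc(NC(=O)Nc4cccc(C(F)(F)F)c4)c3)cc2-c2ccncc2)c1`, -11.5%
compound 2 `COc1cc(Cl)cc(-c2nn(-c3cccc(NC(=O)c4cccc(C(F)(F)F)c4)c3)cc2-c2ccncc2)c1`, 74.5%
compound 3 `O=C(Nc1cccc(-n2cc(-c3ccncc3)c(-c3cc(O)cc(Cl)c3)n2)c1)Nc1ccc(Cl)c(Cl)c1`, -61.8%

In a functional assay on UACC-62 cells (Homo sapiens) for inhibition, read by sulforhodamine B assay, with a stated time of 48 h, tested at 10 uM (a lower number here means a stronger effect, a higher number a weaker effect of the compound at the concentration tested), compound 3 gives the lowest of the three numbers, with compound 1 nearest and compound 2 furthest away. Compound 4 `COc1cc(Cl)cc(-c2nn(-c3cccc(NC(=O)Nc4ccc(Cl)c(Cl)c4)c3)cc2-c2ccncc2)c1` is derived from compound 3 by one change: methyl in place of hydrogen on an oxygen on an aromatic ring. Going by the values given here, the only measured step, a number 86 percentage points higher from compound 1 to compound 2 (beyond the scatter), concerns the carbonyl linker, not the oxygen on the aromatic ring, so no measured step bears on this change. The shift in compound 4 is therefore expected to stay within the scatter, a number 11.8 percentage points higher from compound 3 to compound 4 (beyond the scatter). Compound 4 is estimated at -50%, within a range from -90% to -5%.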

Compound 4, a percentage reported as activity, at one concentration (the size of the read-out at that concentration, not a potency): 4.38%
Estimate against measurement, compound 4: 54.4 percentage points below; measured number outside the range, above it.
By their numbers in this assay, from the lowest: compound 3; then compound 1; then compound 4; then compound 2.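

In this assay, the hydroxy on the 3-chloro-5-hydroxyphenyl group proves to be a sensitive point: methyl in place of its hydrogen gives a number 66.2 percentage points higher from compound 3 to compound 4 (beyond the scatter), a large step from a single added carbon. With the methoxy kept, (3,4-dichlorophenyl)amino in place of 3-(trifluoromethyl)phenyl on the carbonyl carbon gives a number 70.1 percentage points lower from compound 2 to compound 4 (beyond the scatter), so the urea keeps much of the effect, while 3,4-dichlorophenyl in place of 3-(trifluoromethyl)phenyl on the amide-type nitrogen gives only a modest a number 15.9 percentage points higher from compound 1 to compound 4 (beyond the scatter). As far as these compounds go, it remains open how an amine or an ethoxy group would read at this position. Nothing available accounts for the step from hydroxy to methoxy.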